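A few compounds are considered here, and "the series" means these few. Any claim that something is new, unique, unknown or untested is made for them only; others in the source may bear on it.

Working notes on the series. Compound 1 `CNc1nc(NCCCN(C)C)c2sc(-c3ccc(N)cc3)cc2n1` and compound 2 `CNc1nc(NCCCN(C)C)c2sc(-c3ccc(C(C)=O)cc3)cc2n1` share one core and differ only in the group carried on the five-membered ring. In a physicochemical assay for solubility, at pH 2 (on this read-out higher numbers stand for higher solubility and lower numbers for lower solubility), compound 1 gives > 100 ug/mL, which is a limit of the assay and not a number. In this assay compound 2 likewise gives > 100 ug/mL, again a limit rather than a number. The step that the two limits leave unreadable from compound 1 to compound 2 therefore cannot be read, since the limit of > 100 ug/mL in this assay, at which 2 of the 2 values shown sit, covers both values. Among the compounds with values here, compound 2 thus stands at the limit of the read-out, with no member of the series reported as a plain number.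

Compound 3 `CNc1nc(NCCCN(C)C)c2sc(-c3cncnc3)cc2n1` is the unmeasured member. The change is pyrimidin-5-yl in place of 4-acetylphenyl on an aromatic carbon. Within the data shown here, no measured step carries the same change; the only measured step, a step that the two limits leave unreadable from compound 1 to compound 2, is itself unreadable, so it neither supports nor opposes a shift. The expectation for this assay is a step that the limit leaves unreadable from compound 2 to compound 3 that stays within the scatter, with the value most probably again reported as a limit. Compound 3 is estimated at 150 ug/mL, with a range from 60 ug/mL to 400 ug/mL.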

Compound 3, solubility: 214 ug/mL
Compound 3: middle estimate off by 1.4-fold (0.15 log units), on the low side, within the range that was stated.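

No new step can be read in this assay: the steps from compound 1 and from compound 2 to compound 3 stay unreadable because those two compounds are reported only as limits: the limit of > 100 ug/mL in this assay, at which 2 of the 3 values shown sit.

The compounds shown leave open how far compound 1 and compound 2 lie from compound 3 in this assay, and in which direction.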